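Chloro position on the arylpiperazine of the oxindole series

A few compounds are considered here, and "the series" means these few. Any claim that something is new, unique, unknown or untested is made for them only; others in the source may bear on it.

Measured compounds:
- compound 1 `CCC1(CCCCN2CCN(c3ccc(Cl)cc3)CC2)C(=O)Nc2ccccc21`: 10 mg/kg
- compound 2 `CC(C)CC1(CCCCN2CCN(c3cccc(Cl)c3)CC2)C(=O)Nc2ccccc21`: 10 mg/kg
- compound 3 `CCC1(CCCCN2CCN(c3ccc(F)cc3)CC2)C(=O)Nc2ccc(F)cc21`: > 20 mg/kg

In a functional assay on the whole organism (strain Wistar) with Rattus norvegicus as the target, with a stated time of 5 min (a lower number here means that less compound is needed, a higher number that more compound is needed for the effect), compound 1 gives 10 mg/kg, level with compound 2 at the digits shown, the two lying within the scatter of each other. Compound 3 reaches only a limit of this assay (the limit of > 20 mg/kg in this assay, at which 1 of the 3 values shown sits), so no number stands for it. Compound 4 `CCC1(CCCCN2CCN(c3ccccc3Cl)CC2)C(=O)Nc2ccccc21` has not been tested; it differs from compound 1 in one place (2-chlorophenyl in place of 4-chlorophenyl on an amine nitrogen in a ring).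

Within the data shown here, no step between measured compounds isolates this change, so the size and direction are open. The expectation is a step from compound 1 to compound 4 of no change at the digits printed from compound 1 to compound 4 (within the scatter), that is, no move beyond the scatter. Compound 4 is estimated at 10 mg/kg, with a range from 5 mg/kg to 20 mg/kg.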

Compound 4, minimum effective dose: > 20 mg/kg
Compound 4: no number, only a limit; the forecaster's own chance of this, stated with the estimate: 25%; middle value at least 2.0-fold (0.30 log units) from the limit.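

In this assay compound 4 gives > 20 mg/kg, which is a limit and not a number. The change from 4-chlorophenyl to 2-chlorophenyl on the amine nitrogen in a ring can therefore be read only as a floor, an at least 2.0-fold higher number from compound 1 to compound 4 (0.30 log units; that floor lies within the scatter), so its direction is indicated but its true size remains unfixed. This limit now recurs in the series: the limit of > 20 mg/kg in this assay, at which 2 of the 4 values shown sit.

Still open, from the compounds shown here alone, is how large the step really is. Also open, going by these compounds, is whether 2-methoxyphenyl or plain phenyl at this place would give a number rather than a limit.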